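Replacing the cyanopyridinyl arm with pyrimidinyl

A few compounds are considered here, and "the series" means these few. Any claim that something is new, unique, unknown or untested is made for them only; others in the source may bear on it.

The measured compounds and their numbers:
- compound 1, `O/N=C(/CCN1CCN(c2ccccn2)CC1)c1ccccc1Cl`, gives 25 nM in a functional assay on HEK293 cells with D(4) dopamine receptor (Homo sapiens) as the target, read by FLIPR; on this read-out lower numbers stand for an effect already at smaller amounts and higher numbers for an effect only at larger amounts of compound
- compound 2, `N#Cc1cccnc1N1CCN(CC/C(=N\O)c2ccccc2)CC1`, gives 18 nM in this assay
- compound 3, `N#Cc1cccnc1N1CCN(CC/C(=N/O)c2ccccc2)CC1`, gives 20 nM in this assay

Compound 3 stands second highest of the three numbers in this assay, though all three lie within the scatter of one another, so no order among them can be read. Within the data shown here, the only step between two compounds that differ in one place is a 1.1-fold higher number from compound 2 to compound 3 (0.05 log units; within the scatter), and it rests on the fact that compounds 2 and 3 differ only in the configuration as drawn: the geometry of the oxime double bond leaves the number unchanged.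

Compound 4, `O/N=C(/CCN1CCN(c2ncccn2)CC1)c1ccccc1`, differs from compound 3 in pyrimidin-2-yl in place of 3-cyanopyridin-2-yl on an amine nitrogen in a ring. Among the measured compounds shown here, no measured step covers this change; compound 1 carries a different arm on the same ring nitrogen together with a chlorine on the other aryl ring, so its number against compound 3 speaks to two changes at once and not to this one alone. With the three measured numbers sitting so close, nothing in the data points to a large move in either direction, and the expectation is a number near that of compound 3, with a wide band to reflect the untested arm.

Compound 4 is therefore expected to give 30 nM in this assay, within 8 nM to 120 nM, which would be a step of a 1.5-fold higher number from compound 3 to compound 4 (0.18 log units; within the scatter) and is expected to stay within the scatter.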

Compound 4, half-maximal effective concentration: 69 nM
The estimate for compound 4 lay 2.3-fold (0.36 log units) below the measured number, and the stated range covers the measured number.
By their numbers in this assay, from the lowest: compounds 2, 3 and 1 (each within the scatter of the next); then compound 4.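

Pyrimidin-2-yl in place of 3-cyanopyridin-2-yl on the amine nitrogen in the ring gives a 3.5-fold higher number from compound 3 to compound 4 (0.54 log units; beyond the scatter) in this assay, the first step among these compounds to lie beyond the scatter, whereas the change in oxime geometry, a 1.1-fold higher number from compound 2 to compound 3 (0.05 log units; within the scatter), stayed within it. Among these compounds, the number therefore responds to what is carried on this ring nitrogen, a sensitivity that the earlier compounds could not show, although the size of the step is modest. The exchange removes the nitrile and brings a second hetero atom into the six-membered aromatic ring in a single move, and nothing in the data shown bears on why the number moves.

As far as these compounds go, it remains open whether the step belongs to the loss of the nitrile, to the added ring nitrogen or to both, and a 5-cyanopyrimidin-2-yl arm on the same nitrogen would separate these two parts. Also open, from the compounds shown here alone, is how a phenyl or a 3-methoxypyridin-2-yl arm would fare on the shared core, with the aryl ring on the oxime carbon left unsubstituted.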